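The source may report more compounds than this note shows. Statements on the series, on what has been measured and on what is new or still open speak of the compounds shown alone.

Three compounds have been measured in an assay on isolated protein for inhibition of Ca2+/calmodulin-dependent protein kinase II (CaM kinase II) (Rattus norvegicus), tested at 30 uM; on this read-out lower numbers stand for less inhibition and higher numbers for more inhibition at the one concentration tested (going by the name of the read-out):

compound 1 `Cn1cnc2c(SCc3ccccc3)ncnc21` gives 0%
compound 2 `Cn1cnc2c(SCc3ccc(F)cc3)ncnc21` gives 5%
compound 3 `c1ccc(Cn2cnc3c(Sc4ccccc4)ncnc32)cc1` gives 3%

Compound 1 and compound 2 share a core and differ in one place only: fluoro in place of hydrogen on an aromatic carbon. The step that this change made is a number 5 percentage points higher from compound 1 to compound 2 (within the scatter), so the two numbers cannot be told apart by this assay. Compound 3 carries a different core; the difference between the two cores is not broken down here. Its number in this assay is close to those of compound 1 and compound 2, all three lying within the usual scatter of one another, so no order among them can be claimed.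

Compound 4 `Fc1ccc(Cn2cnc3c(Sc4ccccc4)ncnc32)cc1` has not yet been measured. It differs from compound 3 in exactly one place: fluoro in place of hydrogen on an aromatic carbon. This is the same change that turns compound 1 into compound 2, and the place where the fluorine enters is described in the same words for both pairs, so it counts as the same change made on a second core. Because a number 5 percentage points higher from compound 1 to compound 2 (within the scatter) was within the scatter, the expectation is that the step from compound 3 to compound 4 in this assay will also be small, roughly a number 2 percentage points higher from compound 3 to compound 4 (within the scatter). On that basis compound 4 is estimated to give about 5%, with a likely range from 0% to 15%.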

Compound 4, a percentage reported as inhibition, at one concentration (the size of the read-out at that concentration, not a potency): 0%
Beside the measured number, compound 4's estimate is 5 percentage points above it, within the range that was stated.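

On the second core, fluoro in place of hydrogen on an aromatic carbon gives a number 3 percentage points lower from compound 3 to compound 4 (within the scatter), so in this assay this step cannot be told apart from the ordinary spread of repeated measurements. Set beside the earlier step, it shows that the change behaves alike on the two cores as far as this read-out can tell, with neither step standing out and no real difference between them: the same change on two cores in this assay, a number 5 percentage points higher (within the scatter) from compound 1 to compound 2 and a number 3 percentage points lower (within the scatter) from compound 3 to compound 4, 8 percentage points apart, within the scatter of two such steps. This is agreement between two steps too small to read, with all four compounds giving small numbers at the one concentration tested, so it does not show that an effect of fluoro carries from one core to the other, nor that fluoro has any effect here at all.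

The compounds shown carry only hydrogen or fluoro at this place on the ring, which leaves open whether an amine, a carboxylic acid or a longer chain there would give a number clearly beyond the scatter. Going by these compounds, it also remains open whether the two cores would still respond alike to a change that moves the number by a readable amount.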